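Truncating the sulfone side chain of compound 3

The source may hold more compounds than are shown below. What is called first, only, known or untested is meant among the compounds shown, and "the series" means these compounds.

Going by the values given here, compound 3 `O=S1(=O)CCC(CNCCCCN(C[C@H]2Cc3ccccc3CN2)[C@H]2CCCc3cccnc32)CC1` gives 17 nM in a functional assay on cells for antagonist activity at C-X-C chemokine receptor type 4 (Homo sapiens), read by fluorescence and calcium flux, with stated times of 25 min and 90 s (on this read-out lower numbers stand for stronger inhibition and higher numbers for weaker inhibition), the lowest of the three numbers measured so far. Compound 2 `c1ccc2c(c1)CN[C@@H](CN(CCCCNCC1CCSCC1)[C@H]1CCCc3cccnc31)C2` gives 69.6 nM, and the step of a 4.1-fold lower number from compound 2 to compound 3 (0.61 log units; beyond the scatter) came with 1,1-dioxothian-4-yl in place of thian-4-yl on a saturated chain carbon bound to an amine nitrogen. Compound 1 `c1cncc(CN(CCCCN(C[C@H]2Cc3ccccc3CN2)[C@H]2CCCc3cccnc32)Cc2cccnc2)c1` gives 471 nM, a much higher number than compound 3.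

Compound 4 `CC(C)(CN)CCN(C[C@H]1Cc2ccccc2CN1)[C@H]1CCCc2cccnc21` differs from compound 3 by a group of 5 heavy atoms (4 carbon, 1 nitrogen; no ring) in place of a group of 12 heavy atoms (8 carbon, 1 nitrogen, 2 oxygen, 1 sulfur; one six-membered non-aromatic ring with 1 hetero atom), on a saturated chain carbon, two bonds along the chain from an amine nitrogen. Among the compounds with values here, no measured step covers such a change: the only step known concerns the ring that is now removed altogether, and it shows that the number moved when that ring was altered. Removing the ring and its sulfur-bearing part while keeping a primary amine is therefore expected to cost potency, with the size of the loss uncertain. The expected step is a 5.3-fold higher number from compound 3 to compound 4 (0.72 log units; beyond the scatter). For compound 4 the estimated value in this assay is 90 nM, within a range from 20 nM to 400 nM.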

Compound 4, half-maximal inhibitory concentration: 69 nM
Compound 4: middle estimate off by 1.3-fold (0.12 log units), on the high side; the measured number falls inside the stated range.
By their numbers in this assay, from the lowest: compound 3; then compounds 4 and 2 (each within the scatter of the next); then compound 1.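

In working terms, activity at this position on a saturated chain carbon, two bonds along the chain from an amine nitrogen, does not depend on a ring: in this assay, 1-(aminomethyl)-1-methylethyl replaces the whole sulfone-bearing group with a 4.1-fold higher number from compound 3 to compound 4 (0.61 log units; beyond the scatter) as the result. Replacing the thian-4-yl-bearing group with the same open-chain group gives a 1.0-fold lower number from compound 2 to compound 4 (0.00 log units; within the scatter) and so leaves the read-out unchanged, which makes the 1,1-dioxothian-4-yl group of compound 3 the only one of these three that stands apart. No measured property accounts for either step.

Still open, from the compounds shown here alone, is whether the advantage of compound 3 belongs to the sulfone itself or to other polar rings. Also open, going by these compounds, is how a piperidine ring, a carboxylic acid or a longer unbranched chain ending in an amine would read at this position.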